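The source may report more compounds than this note shows. Statements on the series, on what has been measured and on what is new or still open speak of the compounds shown alone.

Measured in an assay on isolated protein for binding affinity to melatonin receptor type 1A (Homo sapiens); on this read-out lower numbers stand for stronger inhibition and higher numbers for weaker inhibition:
compound 1, `C/C=C/C(=O)Nc1ccc(Oc2cccc(OC)c2)cc1`: compound 1 gives 98 nM
compound 2, `CCC(=O)Nc1ccc(Nc2cccc(OC)c2)cc1`: compound 2 gives 61 nM
compound 3, `COc1cccc(N(C)c2ccc(NC(C)=O)cc2)c1`: compound 3 gives 0.05 nM

Compound 3 stands lowest of the three numbers in this assay. The nearest number is that of compound 2, and the furthest is that of compound 1; both gaps lie well beyond the usual scatter, so compound 3 is the most potent of the three measured compounds. Within the data shown here, no two of the measured compounds differ in a single place, so no measured step is available for any single structural change.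

Compound 4, `CCC(=O)Nc1ccc(N(C)c2cccc(OC)c2)cc1`, has not yet been measured in this assay. It differs from compound 3 by methyl in place of hydrogen on a saturated chain carbon bound to a carbonyl carbon. Among the measured compounds shown here, no measured pair isolates this change, so its size can only be guessed from the structures alone. Given the very low number of compound 3 at 0.05 nM, the change from acetamido to propanoylamino is expected to leave the number roughly where it is, with any step from compound 3 to compound 4 expected to stay within the scatter, a 1.2-fold higher number from compound 3 to compound 4 (0.08 log units; within the scatter). Compound 4 is therefore estimated at 0.06 nM, with a range from 0.01 nM to 0.4 nM.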

Compound 4, inhibition constant: 1 nM
Compound 4: middle estimate off by 17-fold (1.22 log units), on the low side; measured number above the stated range.
By their numbers in this assay, from the lowest: compound 3; then compound 4; then compounds 2 and 1 (each within the scatter of the next).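

Methyl in place of hydrogen on a saturated chain carbon bound to a carbonyl carbon, the change from acetamido to propanoylamino, gives a 20-fold higher number from compound 3 to compound 4 (1.30 log units; beyond the scatter) in this assay, so this position on the amide side responds strongly to one added carbon and the affinity of compound 3 does not carry over to its propanoylamino counterpart. With propanoylamino held constant, methyl in place of hydrogen on a nitrogen on an aromatic ring gives a 61-fold lower number from compound 2 to compound 4 (1.79 log units; beyond the scatter), a large step in the opposite direction, which makes this nitrogen a second position where a single methyl changes the number well beyond the scatter. No available measurement accounts for either step.

The compounds shown leave open how the number moves with a longer chain such as butanoylamino, or with an ethyl group in place of the methyl on the nitrogen. Among these compounds, they also leave open whether the nitrogen methyl gives a step of similar size with acetamido in place, as the only reading of that change here has propanoylamino on the other end of the molecule.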